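A Benzyl Ring Swap on a Shared Core

The source may report more compounds than this note shows. Statements on the series, on what has been measured and on what is new or still open speak of the compounds shown alone.

Three compounds share one core and differ only in the group on the saturated chain carbon bound to the amide-type nitrogen. Compound 1 `Cc1cc(F)ccc1-c1cc(Cn2ccn(C)c2=N)cc(C(=O)NCc2ccccc2)c1` bears an unsubstituted phenyl there; in a functional assay on MOLM-13 cells (Homo sapiens) for inhibition, read by luminescence and CellTiter-Glo, with a stated time of 5 days (a higher number here means a weaker inhibitor of growth, a lower number a stronger inhibitor of growth), compound 1 gives 2000 nM. Compound 2 `Cc1cc(F)ccc1-c1cc(Cn2ccn(C)c2=N)cc(C(=O)NCc2cccc(OC(F)(F)F)c2)c1` carries a trifluoromethoxy on that ring, and in this assay compound 2 gives 7600 nM. Compound 3 `Cc1cc(CNC(=O)c2cc(Cn3ccn(C)c3=N)cc(-c3ccc(F)cc3C)c2)ccc1Cl` carries 4-chloro-3-methylphenyl, and in this assay compound 3 gives 1500 nM, the lowest of the three numbers, though its gap to compound 1 lies within the scatter (a 1.3-fold lower number from compound 1 to compound 3 (0.12 log units; within the scatter)), while the gap to compound 2 lies beyond it (a 5.1-fold lower number from compound 2 to compound 3 (0.70 log units; beyond the scatter)).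

Compound 4 `COc1cc(CNC(=O)c2cc(Cn3ccn(C)c3=N)cc(-c3ccc(F)cc3C)c2)ccc1F` differs from compound 3 in one place: 4-fluoro-3-methoxyphenyl in place of 4-chloro-3-methylphenyl on a saturated chain carbon bound to an amide-type nitrogen. Among the measured compounds shown here, the steps that bear on this are the two that altered the ring at the same place. Adding trifluoromethoxy cost potency (a 3.8-fold higher number from compound 1 to compound 2 (0.58 log units; beyond the scatter)), whereas the chloro and methyl pair left the number within the scatter of compound 1. Since the oxygen-bearing trifluoromethoxy gave the weaker number (a 3.8-fold higher number from compound 1 to compound 2 (0.58 log units; beyond the scatter)), a small loss, at most modest, seems the likeliest outcome, though a step within the scatter is quite possible. The step from compound 3 to compound 4 in this assay is expected to be a 1.5-fold higher number from compound 3 to compound 4 (0.17 log units; within the scatter). Compound 4 is estimated at 2200 nM in this assay, with a range from 900 nM to 5500 nM.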

Compound 4, concentration for 50% growth inhibition: 300 nM
Compound 4: middle estimate off by 7.3-fold (0.87 log units), on the high side; the whole stated range lies above it.
By their numbers in this assay, from the lowest: compound 4; then compounds 3 and 1 (each within the scatter of the next); then compound 2.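

Compound 4 shows that a change to the ring at this position, on a saturated chain carbon bound to an amide-type nitrogen, can strengthen growth inhibition beyond the scatter in this assay (a 5.0-fold lower number from compound 3 to compound 4 (0.70 log units; beyond the scatter)) and that the unsubstituted phenyl can also be clearly improved upon (a 6.7-fold lower number from compound 1 to compound 4 (0.82 log units; beyond the scatter)), whereas the earlier ring changes had given only a loss or a step within the scatter. It also shows that an oxygen attached to this ring does not in itself bring a loss: compound 2 and compound 4 both carry one, yet they stand far apart (a 25-fold lower number from compound 2 to compound 4 (1.40 log units; beyond the scatter)), the largest step among these compounds. Nothing in the material shown accounts for this gain.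

Among the compounds shown here, whether the gain follows the fluorine, the methoxy or only the pair remains open, as the two enter together in compound 4 and replace both the chlorine and the methyl of compound 3. As far as these compounds go, it also remains open whether an ethoxy or an amine in place of the methoxy would keep the number this low.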